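The compounds below may be only part of what the source reports. "The series", "measured", "known", "first", "only" and "open" are said of these compounds alone.

Measured so far:
compound 1, `Clc1ccc(C(/C=C/c2ccccc2)=N\Nc2nncc3ccccc23)cc1`: 4.6 nM
compound 2, `O=S(=O)(Nc1ccccn1)c1ccc(Nc2nncc3ccccc23)cc1`: 54 nM

In a functional assay on DU-145 cells (Homo sapiens) for antiproliferative activity, read by sulforhodamine B assay, with a stated time of 72 h (a lower number here means a stronger inhibitor, a higher number a weaker inhibitor), compound 1 gives 4.6 nM. In this assay compound 2 gives 54 nM. Compound 2 thus carries the higher of the two numbers, and the gap to compound 1 lies beyond the scatter of the method. Compound 1 and compound 2 differ from each other in more than one place, so their two values show only the gap itself and no single step can be read from them.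

Compound 3, `O=S(=O)(Nc1nccs1)c1ccc(Nc2nncc3ccccc23)cc1`, is the next member awaiting measurement in this assay. It differs from compound 2 in one place: 1,3-thiazol-2-yl in place of pyridin-2-yl on a sulfonamide nitrogen.

Within the data shown here, nothing among the measured pair bears directly on this exchange; no step of this kind has been measured. Starting from compound 2 at 54 nM, the step from compound 2 to compound 3 is expected to be small, a 1.1-fold lower number from compound 2 to compound 3 (0.03 log units; within the scatter), with no change beyond the scatter in either direction.

Compound 3 is therefore estimated at 50 nM, with a range from 15 nM to 170 nM.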

Compound 3, half-maximal inhibitory concentration: 24 nM
Estimate against measurement, compound 3: 2.1-fold (0.32 log units) above; low and high end bracket the measured number.
By their numbers in this assay, from the lowest: compound 1; then compound 3; then compound 2.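

In this assay, among these compounds, the exchange of pyridin-2-yl for 1,3-thiazol-2-yl on a sulfonamide nitrogen gives a 2.3-fold lower number from compound 2 to compound 3 (0.35 log units; beyond the scatter) and provides the first step that can be read at a single place. It shows that the number responds to the aromatic ring on this nitrogen, though the change is modest. The exchange alters ring size, hetero atom count and element content together, with a five-membered ring holding nitrogen and sulfur replacing a six-membered ring holding nitrogen alone, so the step belongs to the exchange as a whole and cannot be divided among these features. No measured evidence at hand accounts for the step.

Still open, from the compounds shown here alone, is whether an aromatic ring is needed on this nitrogen at all, which a plain phenyl ring, a short alkyl chain or a simple hydrogen in its place would test. Also open, going by these compounds, is whether a methyl group or a carboxylic acid on the 1,3-thiazol-2-yl ring would move the number further in either direction.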